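Compound 2 and a longer chain on its amide

The compounds below may be only part of what the source reports. "The series", "measured", "known", "first", "only" and "open" are said of these compounds alone.

- compound 1 `C[C@H](CO)NC(=O)c1c(O)c2ncc(Cc3ccc(F)cc3)cc2[nH]c1=O` at 6370 ng.h/mL
- compound 2 `C[C@@H](CO)NC(=O)c1c(O)c2ncc(Cc3ccc(F)cc3)cc2n(C)c1=O` at 22600 ng.h/mL
- compound 3 `Cn1c(=O)c(C(=O)NCCO)c(O)c2ncc(Cc3ccc(F)cc3)cc21` at 22800 ng.h/mL

In an ADME assay on the whole organism (plasma, strain CD) for pharmacokinetics, with Rattus norvegicus as the target, at a dose of 5 mg/kg by the oral route (on this read-out lower numbers stand for lower exposure and higher numbers for higher exposure at the dose given), compound 2 gives 22600 ng.h/mL and so stands within the scatter of compound 3 and beyond the scatter above compound 1. Compound 4 `C[C@@H](CO)CNC(=O)c1c(O)c2ncc(Cc3ccc(F)cc3)cc2n(C)c1=O` has not yet been measured. It carries 2-(hydroxymethyl)propyl in place of 1-(hydroxymethyl)ethyl on an amide-type nitrogen. Among the compounds with values here, only one measured step touches this chain: hydrogen in place of methyl gave a 1.0-fold higher number from compound 2 to compound 3 (0.00 log units; within the scatter) and so no change beyond the scatter. Within the data shown here, that is a different change from the one in compound 4, so it guides only loosely. No step beyond the scatter is therefore expected in this assay in either direction. The estimate means a step of a 1.3-fold lower number from compound 2 to compound 4 (0.10 log units; within the scatter) and this is expected to stay within the scatter. For compound 4 the estimated value is 18000 ng.h/mL with an expected range from 7000 ng.h/mL to 42000 ng.h/mL in this measurement.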

Compound 4, area under the concentration-time curve: 12600 ng.h/mL
For compound 4 the middle estimate is 1.4-fold (0.15 log units) above the measured one; the measured number falls inside the stated range.
By their numbers in this assay, from the lowest: compounds 1, 4, 2 and 3 (each within the scatter of the next, the first and the last beyond it).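

In this assay, 2-(hydroxymethyl)propyl in place of 1-(hydroxymethyl)ethyl on the amide-type nitrogen gives a step within the scatter (a 1.8-fold lower number from compound 2 to compound 4 (0.25 log units; within the scatter)). The comparison with the hydroxymethyl-bearing chain of compound 3 reads the same way, for 1-(hydroxymethyl)ethyl in place of hydroxymethyl on a saturated chain carbon bound to an amide-type nitrogen (a 1.8-fold lower number from compound 3 to compound 4 (0.26 log units; within the scatter)). Where the earlier pair covered only the loss of one methyl, compound 2, compound 3 and compound 4 now show three different hydroxyl-bearing chains at this place, none beyond the scatter of the others.

Going by these compounds, whether a chain ending in an amine or a carboxylic acid, or a plain propyl chain without the hydroxyl, would read alike here remains open. No supporting data bear on why these chains give such similar exposure.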